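The compounds below may be only part of what the source reports. "The series", "measured", "known", "first", "only" and "open" are said of these compounds alone.

Of the compounds shown here, three sharing one core have been measured in a functional assay on HCT-116 cells (Homo sapiens) for cytotoxicity, read by MTT assay, with a stated time of 72 h; a higher number here means a weaker inhibitor, a lower number a stronger inhibitor. Compound 1 `CCOc1cccc(/C=N/c2c(C)n(C)n(-c3ccccc3)c2=O)c1` gives 933000000 nM in this assay, the highest of the three numbers. Compound 2 `COc1cc(/C=N/c2c(C)n(C)n(-c3ccccc3)c2=O)ccc1O` gives 468000000 nM in this assay, a value that lies within the scatter of the number for compound 1. Compound 3 `COc1ccccc1/C=N/c1c(C)n(C)n(-c2ccccc2)c1=O` gives 324000000 nM in this assay, a number that lies beyond the scatter below that of compound 1. Among the compounds with values here, no pair of measured compounds differs in a single place, so no measured step guides the next comparison. Compound 4 `Cc1c(/N=C/c2cccc([N+](=O)[O-])c2)c(=O)n(-c2ccccc2)n1C` has not yet been measured in this assay. It differs from compound 1 in one place: nitro in place of ethoxy on an aromatic carbon. Within the data shown here, nothing among the measured compounds shows the effect of such an exchange, so the step expected in this assay is small, in no fixed direction, and probably within the scatter. The expected step in this assay is a 1.3-fold lower number from compound 1 to compound 4 (0.12 log units; within the scatter). On that basis the value expected for compound 4 in this assay is 700000000 nM, with a range from 250000000 nM to 2000000000 nM.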

Compound 4, half-maximal inhibitory concentration: 363000000 nM
Compound 4: the middle estimate sits 1.9-fold (0.29 log units) above what was measured; low and high end bracket the measured number.
By their numbers in this assay, from the lowest: compounds 3, 4, 2 and 1 (each within the scatter of the next, the first and the last beyond it).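

Within the data shown here, replacing ethoxy with nitro on an aromatic carbon, meta to a large group, gives the first measured single-place step in this assay: a 2.6-fold lower number from compound 1 to compound 4 (0.41 log units; beyond the scatter). The number at this position therefore responds to the exchange, and the modest step lies beyond the scatter even though the two groups have the same count of heavy atoms and neither carries a ring, a hydrogen-bond donor or a net charge. Nothing available explains why the number moves with this exchange.

The compounds shown give only this one exchange at this position, so a single step cannot set a trend for other groups there. From the compounds shown here alone, whether an amine, a carboxylic acid or a longer chain in place of ethoxy would lower the number further, or raise it, remains open.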